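The source may hold more compounds than are shown below. What is called first, only, known or untested is meant among the compounds shown, and "the series" means these compounds.

Series notes in a functional assay on the whole organism for inhibition, with Rattus norvegicus as the target, at a dose of 20 mg/kg by the oral route; on this read-out higher numbers stand for more inhibition at the one dose given (going by the name of the read-out) and lower numbers for less inhibition. Compound 1 `CNC(=O)/C=C1\CCc2c(C)cc(F)cc21` gives 77%. Compound 2 `O=C(/C=C1\CCc2cc(Cl)c(F)cc21)NC1CC1` gives 27%, and compound 3 `CNC(=O)/C=C1\CCc2cc(Cl)cc(Cl)c21` gives 22%. On these three numbers compound 2 stands second; its value and that of compound 3 lie within the scatter of each other, so no order is read between them, whereas compound 1 stands clear above compound 2, a gap beyond the scatter.

Compound 4 `CNC(=O)/C=C1\CCc2cc(Cl)c(F)cc21` is not yet measured in this assay. Against compound 2 the change is methyl in place of cyclopropyl on an amide-type nitrogen. For the measured compounds named here, no measured pair in the set carries this change on a shared core, so its size cannot be read from the data. The methylcarbamoyl group is present in both compound 1 and compound 3, whose values lie far apart, so the amide group by itself does not fix the level in this assay; the core substitution of compound 4 matches that of compound 2, not that of compound 1.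

The step of a number 13 percentage points higher from compound 2 to compound 4 (beyond the scatter) is expected to be small and upward, near the edge of the scatter rather than clearly beyond it. Compound 4 is accordingly estimated at 40%, with a range from 15% to 70% to cover the unknown size of the change.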

Compound 4, a percentage reported as inhibition, in the whole organism at one dose (the size of the read-out at that dose, not a potency): 22%
For compound 4 the middle estimate is 18 percentage points above the measured one; the measured number falls inside the stated range.
By their numbers in this assay, from the lowest: compounds 3, 4 and 2 (each within the scatter of the next); then compound 1.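

In this assay the exchange of cyclopropyl for methyl on an amide-type nitrogen can now be read on a shared core: a number 5 percentage points lower from compound 2 to compound 4 (within the scatter) is a step that lies within the scatter. For this core, the three-membered ring and its 3 carbons can therefore give way to a single methyl carbon without a difference that this read-out can resolve, although this rests on one pair only. No measurement bearing on this result is at hand, so the compounds shown offer no explanation for it.

From the compounds shown here alone, whether the same exchange would read alike on the core of compound 1, which gives 77% in this assay, remains open, and the steps among the other compounds cannot be read, as those pairs differ in more than one place. Also open, going by these compounds, is how a longer chain such as n-butyl, a chain ending in an amine or a carboxylic acid, or a plain hydrogen in place of the cyclopropyl on this nitrogen would read on the core shared by compound 2 and compound 4.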